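The compounds below may be only part of what the source reports. "The series", "measured", "known", "first", "only" and "open" are said of these compounds alone.

Measured compounds:
Compound 1, `c1ccc(CSc2nnc(Cc3ccccc3Oc3ccccc3)[nH]2)cc1`, in a functional assay on the whole organism (strain NMRI) with Mus musculus as the target, with a stated time of 60 min, at a dose of 20 mg/kg by the intraperitoneal route; a lower number here means a weaker effect, a higher number a stronger effect of the compound at the dose given: 143%
Compound 2, `CCSc1nnc(Cc2ccc(Cl)cc2Oc2ccccc2Cl)[nH]1`, in this assay: 174%
Compound 3, `CCSc1nnc(Cc2ccc(Cl)cc2Oc2ccccc2F)[nH]1`, in this assay: 141%

Compound 2 stands highest of the three numbers in this assay; its nearest neighbour is compound 1, and both compound 1 and compound 3 lie beyond the scatter below it. Among the compounds with values here, the single one-place step measured so far, a number 33 percentage points lower from compound 2 to compound 3 (beyond the scatter), shows that a small exchange on an aromatic carbon moved the read-out well beyond the scatter.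

Compound 4, `CCOc1nnc(Cc2ccc(Cl)cc2Oc2ccccc2Cl)[nH]1`, differs from compound 2 as follows: ethoxy in place of ethylsulfanyl on an aromatic carbon. Within the data shown here, no measured step touches this position or this exchange, so the step of a number 33 percentage points lower from compound 2 to compound 3 (beyond the scatter) serves only as a gauge of how far a small change on this core can move the number in this assay, not of its direction here. The expectation for compound 4 is therefore a number near that of compound 2 with wide uncertainty, and the estimated step is a number 24 percentage points lower from compound 2 to compound 4 (beyond the scatter). Compound 4 is estimated at 150%, between 100% and 200%.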

Compound 4, a percentage reported as activity, at one dose (the size of the read-out at that dose, not a potency): 135%
Estimate against measurement, compound 4: 15 percentage points above, within the range that was stated.
By their numbers in this assay, from the lowest: compounds 4, 3 and 1 (each within the scatter of the next); then compound 2.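

The position on the five-membered aromatic ring, between two ring nitrogen atoms, now has its first one-place exchange: in this assay, ethoxy in place of ethylsulfanyl gives a number 39 percentage points lower from compound 2 to compound 4 (beyond the scatter). The read-out therefore responds at this position as well as on the aromatic carbon bearing the halogen, even though the two groups match in heavy-atom count and in hydrogen-bond donors and acceptors. No measurement in hand gives a reason for this step.

On these data alone, only ethylsulfanyl and ethoxy are compared here on the same core, so no trend across this position can be drawn, and an amine or a longer chain such as butylsulfanyl remains open. As far as these compounds go, it is also open whether the ethoxy exchange would give a similar step with fluoro in place of chloro, as on the core of compound 3.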